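A few compounds are considered here, and "the series" means these few. Any claim that something is new, unique, unknown or untested is made for them only; others in the source may bear on it.

Three compounds share one core and differ only in the chain attached to the sulfonyl group. Compound 1 `O=S(=O)(/C=C/c1ccc(O)c(O)c1)CC1CCCO1` gives 10500 nM in a functional assay, read by fluorescence and spectrophotometry, with a stated time of 1 h; a higher number here means that more compound is needed for the effect, a lower number that less compound is needed. Compound 2 `CCCCCCS(=O)(=O)/C=C/c1ccc(O)c(O)c1` gives 7300 nM in this assay, and the change between them is small: a 1.4-fold lower number from compound 1 to compound 2 (0.16 log units; within the scatter). Compound 3 `O=S(=O)(/C=C/c1ccc(O)c(O)c1)CCCCCCCCCCCO` gives 22600 nM in this assay, the highest of the three numbers; compound 1 is nearest to it and compound 2 furthest, and the step that separates them is a 3.1-fold higher number from compound 2 to compound 3 (0.49 log units; beyond the scatter).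

Compound 4 `O=S(=O)(/C=C/c1ccc(O)c(O)c1)CCCCCCCO` is the next step from compound 3. The change is hydroxy in place of 4-hydroxybutyl on a saturated chain carbon, seven bonds along the chain from a sulfonyl sulfur. In effect the hydroxyl-bearing chain of compound 3 is cut shorter, bringing the molecule closer in size to compound 2 while keeping a terminal hydroxyl.

Among the compounds with values here, only one measured step bears on this: the addition of a 5-hydroxypentyl to the hexyl chain of compound 2 gave compound 3 a modestly higher number, a 3.1-fold higher number from compound 2 to compound 3 (0.49 log units; beyond the scatter). Removing part of that extension is expected to reverse some of it, so a modest fall in this assay is expected, though not necessarily the full way back to compound 2. Within the data shown here, the terminal hydroxyl remains in compound 4, and no measured step shows what that alone does. Compound 4 is therefore estimated at 12000 nM, within 6000 nM to 25000 nM, an expected step of a 1.9-fold lower number from compound 3 to compound 4 (0.27 log units; within the scatter).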

Compound 4, half-maximal effective concentration: 5900 nM
Compound 4: the middle estimate sits 2.0-fold (0.31 log units) above what was measured, and the stated range ends above it.
By their numbers in this assay, from the lowest: compounds 4, 2 and 1 (each within the scatter of the next); then compound 3.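

Shortening the chain matters at this position: in this assay, hydroxy in place of 4-hydroxybutyl on the saturated chain carbon, seven bonds along the chain from the sulfonyl sulfur, gives a step beyond the scatter (a 3.8-fold lower number from compound 3 to compound 4 (0.58 log units; beyond the scatter)). Compound 3 and compound 4 both end in a hydroxyl, so among these two the higher number goes with the longer chain and not with the hydroxyl itself, and the hydroxyl alone can now be read: hydroxymethyl in place of hydrogen on the hexyl chain of compound 2 leaves the two compounds within the scatter (a 1.2-fold lower number from compound 2 to compound 4 (0.09 log units; within the scatter)). The ring-bearing chain of compound 1 also cannot be told apart from the open chain of compound 4, with 6-hydroxyhexyl in place of oxolan-2-yl (a 1.8-fold lower number from compound 1 to compound 4 (0.25 log units; within the scatter)).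

No measurement is available to explain why the longer chain goes with the higher number. Still open, going by these compounds, is how the number changes with chain lengths other than these, and whether an amine or a carboxylic acid at the end of the chain would behave as the hydroxyl does.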